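A few compounds are considered here, and "the series" means these few. Any claim that something is new, unique, unknown or untested is made for them only; others in the source may bear on it.

Compound 1 `Cc1cccc(C(=O)Nc2cccc(-c3oc4cc(-c5ccc(F)cc5)ccc4c(=O)c3O)c2)c1` gives 10900 nM in a functional assay on GTL 16 cells for antiproliferative activity against GTL 16 cell line (Homo sapiens), read by CCK-8 assay, with a stated time of 72 h; a lower number here means a stronger inhibitor, a higher number a weaker inhibitor. Compound 2 `Cc1cc(C)cc(C(=O)Nc2cccc(-c3oc4cc(-c5ccc(F)cc5)ccc4c(=O)c3O)c2)c1` gives 13500 nM in this assay.

Within the data shown here, compound 2 stands beside compound 1, the only step between them, a 1.2-fold higher number from compound 1 to compound 2 (0.09 log units; within the scatter), lying within the scatter. Compound 3 `O=C(Nc1cccc(-c2oc3cc(-c4ccc(F)cc4)ccc3c(=O)c2O)c1)c1cc(F)cc(F)c1` differs from compound 2 by 3,5-difluorophenyl in place of 3,5-dimethylphenyl on a carbonyl carbon. Among the measured compounds shown here, no measured step swaps methyl for fluorine; the one step known, methyl for hydrogen, changed little. Hence a step of no size beyond the scatter is expected, a 1.1-fold lower number from compound 2 to compound 3 (0.05 log units; within the scatter). Compound 3 is estimated at 12000 nM, within a range from 5000 nM to 30000 nM.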

Compound 3, half-maximal inhibitory concentration: 7410 nM
Beside the measured number, compound 3's estimate is 1.6-fold (0.21 log units) above it; low and high end bracket the measured number.
By their numbers in this assay, from the lowest: compounds 3, 1 and 2 (each within the scatter of the next).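

The step of a 1.8-fold lower number from compound 2 to compound 3 (0.26 log units; within the scatter) and the step of a 1.5-fold lower number from compound 1 to compound 3 (0.17 log units; within the scatter) both come with 3,5-difluorophenyl entering on the carbonyl carbon. So in this assay this position now holds fluorine as well as methyl groups on its phenyl ring, and all three compounds lie within the scatter of one another. Nothing measured alongside these numbers offers an explanation for this. Still open, from the compounds shown here alone, is whether an amine or a carboxylic acid on this ring, or a longer chain in place of the ring, would move the number beyond the scatter.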